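The compounds below may be only part of what the source reports. "The series", "measured", "known", "first", "only" and "open" are said of these compounds alone.

Compound 1 `O=C1C(N2CCCCC2)=CC(=O)c2c1nc1n2[C@H]2OC[C@@H](O)[C@H]2OC1`: in a functional assay on MGC-803 cells (Homo sapiens) for inhibition, read by sulforhodamine B assay (on this read-out lower numbers stand for stronger inhibition and higher numbers for weaker inhibition), compound 1 gives only a limit of the assay, > 4000 nM.
Compound 2 `COc1cccc(NC2=CC(=O)c3nc4n(c3C2=O)[C@H]2OC[C@@H](O)[C@H]2OC4)c1`: in this assay compound 2 gives 1780 nM.
Compound 3 `O=C1C(Nc2ccccc2)=CC(=O)c2c1nc1n2[C@H]2OC[C@@H](O)[C@H]2OC1`: in this assay compound 3 gives 1830 nM.

The value of compound 1 is a limit and not a number (the limit of > 4000 nM in this assay, at which 1 of the 3 values shown sits). Of the two real numbers, compound 2 has the lower one, but compound 3 sits within the usual scatter of it, so the two cannot be told apart. Within the data shown here, the single measured step is an at least 2.1-fold lower number from compound 1 to compound 3 (0.33 log units; beyond the scatter), and it concerns a swap of the whole group on the ring carbon, not the ring that hangs on the amine nitrogen.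

The next compound is compound 4 `CCOc1ccc(NC2=CC(=O)c3nc4n(c3C2=O)[C@H]2OC[C@@H](O)[C@H]2OC4)cc1`, which differs from compound 2 by 4-ethoxyphenyl in place of 3-methoxyphenyl on an amine nitrogen. Among the measured compounds shown here, no measured step concerns such a change on the anilino ring. What can be seen is that compound 3, whose anilino group carries no alkoxy group at all, gives a number within the scatter of compound 2. On that footing the expected step is a 1.0-fold higher number from compound 2 to compound 4 (0.00 log units; within the scatter), that is, none beyond the scatter. Compound 4 is therefore estimated at 1800 nM, with a range from 900 nM to 3800 nM.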

Compound 4, half-maximal inhibitory concentration: 1110 nM
The estimate for compound 4 lay 1.6-fold (0.21 log units) above the measured number; the range from low to high includes it.
By their numbers in this assay, from the lowest: compounds 4, 2 and 3 (each within the scatter of the next). At a limit, above all of these: compound 1.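

In this assay, among these compounds, putting 4-ethoxyphenyl in place of 3-methoxyphenyl on the amine nitrogen gives a 1.6-fold lower number from compound 2 to compound 4 (0.21 log units; within the scatter), the first measured step that concerns the ring on that nitrogen rather than the whole group on the ring carbon. This one swap alters two things together, since methoxy becomes ethoxy and the name of the ring's substitution pattern changes from 3 to 4. Even so, compound 2 and compound 4 cannot be told apart in this assay, so between these two alkoxy-bearing rings the choice shows no measurable consequence for inhibition of these cells.

As far as these compounds go, whether a different kind of group on this ring, such as an amine, a carboxylic acid or a longer alkoxy chain, would shift the number beyond the scatter stays open, and so do the separate contributions of the chain and of its place on the ring. Compound 1 also remains a limit and not a number, so the full distance between it and the anilino compounds is unknown: the limit of > 4000 nM in this assay, at which 1 of the 4 values shown sits.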